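A few compounds are considered here, and "the series" means these few. Any claim that something is new, unique, unknown or untested is made for them only; others in the source may bear on it.

Working notes on the benzamide series in a functional assay on A-375 cells (Homo sapiens) for inhibition, read by CCK-8 assay, with a stated time of 72 h, tested at 8 uM; a lower number here means less inhibition of growth, a higher number more inhibition of growth at the concentration tested. Of the compounds shown here, three carry a number so far. Compound 1 `Nc1ccccc1NC(=O)c1ccc(CSc2nccc(C(F)(F)F)n2)cc1` gives 80.1%. Compound 2 `COc1ccc(SCc2ccc(C(=O)Nc3ccccc3N)cc2)cc1` gives 81.8%. Compound 3 `CC(C)(C)c1ccc(SCc2ccc(/C=C/C(=O)Nc3ccccc3N)cc2)cc1`, whose structure differs from the other two in several places, gives 35.5%. Compound 2 holds the highest of the three numbers; compound 1 sits nearest to it, and the gap between those two values lies within the scatter, so no order between compound 1 and compound 2 can be read from them. Compound 3 lies furthest away, its number well beyond the scatter from that of compound 2. For the measured compounds named here, no two measured compounds differ in one place only, so no single step has yet been priced in this assay.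

Compound 4 `Nc1ccccc1NC(=O)c1ccc(CSc2ccc(F)cc2)cc1` is the next to be measured. Relative to compound 2 the change is fluoro in place of methoxy on an aromatic carbon. Compound 1 and compound 2 carry quite different groups on the sulfur-bound ring yet return values within the scatter of each other, which rests on two compounds only. The expectation for compound 4 is therefore a step from compound 2 that stays within the scatter, in no clear direction. Compound 4 is expected to give 78%, with a range from 62% to 90%. The step this estimate implies is a number 3.8 percentage points lower from compound 2 to compound 4 (within the scatter), expected to be small.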

Compound 4, percent growth inhibition at one concentration: 54.3%
Compound 4: middle estimate off by 23.7 percentage points, on the high side; the measured number lies below the stated range.
By their numbers in this assay, from the lowest: compound 3; then compound 4; then compounds 1 and 2 (each within the scatter of the next).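

Fluoro in place of methoxy provides the first single step in this assay, and it is a number 27.5 percentage points lower from compound 2 to compound 4 (beyond the scatter); this aromatic carbon, para to a large group, therefore responds to the exchange of one small substituent for another. The closeness of the values of compound 1 and compound 2 had left the sulfur-bound ring looking undemanding, but this step shows that the position does not accept every group equally. No available measurement bears on the cause of this step.

With a single exchange at this carbon, the compounds shown do not separate the effect of removing methoxy from that of introducing fluoro, and a plain hydrogen, an ethoxy group or a dimethylamino group at the same place would help to tell these apart. Going by these compounds, it also remains open whether the same exchange gives a step of similar size on the core of compound 3, which differs from compound 2 in more than this one place.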